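Trading Methoxy for Ethyl on the Side Chain

The source may report more compounds than this note shows. Statements on the series, on what has been measured and on what is new or still open speak of the compounds shown alone.

Compound 2 `COCCO/N=C/c1c(N)ncnc1Oc1ccc2[nH]c(C)cc2c1F` stands in the middle of three measured numbers in a functional assay on HCT-116 cells (Homo sapiens) for antiproliferative activity; a higher number here means a weaker inhibitor, a lower number a stronger inhibitor: compound 2 gives 387 nM, while compound 1 `CCO/N=C/c1c(N)ncnc1Oc1ccc2[nH]c(C)cc2c1F` gives 36 nM and compound 3 `CO/N=C/c1c(N)ncnc1Oc1ccc2[nH]ccc2c1` gives 3520 nM. The only single-place step among these runs an 11-fold higher number from compound 1 to compound 2 (1.03 log units; beyond the scatter). Compound 4 `CCCCO/N=C/c1c(N)ncnc1Oc1ccc2[nH]c(C)cc2c1F` differs from compound 2 by ethyl in place of methoxy on a saturated chain carbon, two bonds along the chain from an oxygen on an unsaturated carbon. From the compounds shown here alone, this removes the methoxy whose arrival made compound 2 weaker, yet it also lengthens the chain beyond anything measured here, so the effect of that lengthening is unknown. Because the step of an 11-fold higher number from compound 1 to compound 2 (1.03 log units; beyond the scatter) was large, compound 4 is expected to recover much of what was lost, a step of a 5.5-fold lower number from compound 2 to compound 4 (0.74 log units; beyond the scatter). Compound 4 is estimated at 70 nM, between 20 nM and 250 nM.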

Compound 4, half-maximal inhibitory concentration: 1000 nM
Estimate against measurement, compound 4: 14-fold (1.15 log units) below; the whole stated range lies below it.
By their numbers in this assay, from the lowest: compound 1; then compound 2; then compound 4; then compound 3.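

In this assay, replacing methoxy with ethyl on this chain carbon does not restore strength: the step is a 2.6-fold higher number from compound 2 to compound 4 (0.41 log units; beyond the scatter). Both groups weaken compound 1, but ethyl costs more, at a 28-fold higher number from compound 1 to compound 4 (1.44 log units; beyond the scatter), than methoxy, at an 11-fold higher number from compound 1 to compound 2 (1.03 log units; beyond the scatter), so removing the oxygen does not undo the loss and the butoxy chain remains well short of compound 1. No available measurement explains this order. From the compounds shown here alone, whether a smaller methyl, a hydroxyl or an amine on this carbon would keep the strength of compound 1 remains open.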